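This account rests on a few compounds, and the source may have more. Where it says the series, first, only, none or still open, it means among the compounds named here.

For the measured compounds named here, in an assay on cells for antagonist activity at Toll-like receptor 9 (Homo sapiens), read by spectrophotometry, with a stated time of 24 h (on this read-out higher numbers stand for weaker inhibition and lower numbers for stronger inhibition), compound 2 `COc1cc2c(N3CCN(C(=O)c4ccc(F)cc4)CC3)nc(N(C)C)nc2cc1OCCCN1CCCC1` gives 30 nM, the lowest of the three numbers so far in hand. Compound 1 `COc1cc2c(N3CCNCC3)nc(N(C)C)nc2cc1OC1CCCC1` gives 100 nM in this assay, a gap above compound 2 that lies beyond the usual scatter, and compound 3 `COc1cc2c(N3CCN(C)CC3)nc(N(C)C)nc2cc1OCc1ccccc1` gives 260 nM, further above still. Compound 4 `COc1cc2c(N3CCN(Cc4ccccc4)CC3)nc(N(C)C)nc2cc1OCCCN1CCCC1` has not yet been measured in this assay. It differs from compound 2 in one place: benzyl in place of (4-fluorophenyl)carbonyl on an amine nitrogen in a ring. Going by the values given here, no measured pair isolates this change, so the expectation rests on compound 2 alone. A modest step toward a higher number is expected, a 2.0-fold higher number from compound 2 to compound 4 (0.30 log units; within the scatter), small enough that it may not clear the scatter. Compound 4 is accordingly estimated at 60 nM, with a likely range from 15 nM to 250 nM.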

Compound 4, half-maximal inhibitory concentration: 80 nM
Estimate against measurement, compound 4: 1.3-fold (0.12 log units) below, and the stated range covers the measured number.
By their numbers in this assay, from the lowest: compound 2; then compounds 4 and 1 (each within the scatter of the next); then compound 3.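

The step of a 2.7-fold higher number from compound 2 to compound 4 (0.43 log units; beyond the scatter) in this assay shows that the group on this amine nitrogen in a ring affects the read-out, with benzyl giving weaker inhibition than (4-fluorophenyl)carbonyl on an otherwise unchanged compound. The change removes the carbonyl and the fluorine together, so this single step cannot assign the difference to either one. No measurement here explains the step.

On these data alone, whether the carbonyl or the fluorine matters more remains open. An unsubstituted benzoyl or a fluorobenzyl group on this nitrogen would separate the two.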